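The compounds below may be only part of what the source reports. "The series", "measured", "known", "first", "only" and "open" are said of these compounds alone.

Compound 1 `COc1ccc(C2OC(c3ccc(C)cc3)=NN2C(C)=O)cc1` stands highest of the two numbers recorded: in an in vitro assay on BTI-TN-5B1-4 cells for inhibition of Amine oxidase [flavin-containing] B (Homo sapiens), read by Amplex Red (on this read-out lower numbers stand for stronger inhibition and higher numbers for weaker inhibition), compound 1 gives 74700 nM, whereas compound 2 `CC(=O)N1N=C(c2ccc([N+](=O)[O-])cc2)OC1c1ccc(Cl)cc1` gives 122 nM in this assay, a gap well beyond the scatter. Compound 3 `COc1ccc(C2OC(c3ccccc3)=NN2C(C)=O)cc1` differs from compound 1 by hydrogen in place of methyl on an aromatic carbon. Among the measured compounds shown here, no measured pair shows this change, so the expectation is for no step beyond the scatter in this assay, or at most a slight drift toward weaker inhibition. For compound 3 the estimate is 80000 nM, within 25000 nM to 250000 nM. The expected step is a 1.1-fold higher number from compound 1 to compound 3 (0.03 log units; within the scatter).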

Compound 3, half-maximal inhibitory concentration: 5160 nM
Estimate against measurement, compound 3: 16-fold (1.19 log units) above; measured number outside the range, below it.
By their numbers in this assay, from the lowest: compound 2; then compound 3; then compound 1.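

Going from 4-methylphenyl to phenyl, with hydrogen in place of methyl on an aromatic carbon para to a large group, gives in this assay a 14-fold lower number from compound 1 to compound 3 (1.16 log units; beyond the scatter). Among the compounds shown here, this is the first comparison in which only one place differs, and it shows that inhibition at this position responds strongly to the loss of this single methyl. Nothing measured here accounts for the size of this step. The compounds shown leave open how an ethyl or an amine at this position would compare with hydrogen and methyl. They also leave open whether the same change gives a step of similar size when the other aromatic ring carries a different group.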